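This account rests on a few compounds, and the source may have more. Where it says the series, first, only, none or still open, it means among the compounds named here.

Measured compounds in an ADME assay on MT4 cells (Homo sapiens) for cytotoxicity, read by MTT assay; a higher number here means that more compound is tolerated, a lower number that less compound is tolerated:
compound 1, `CCOC(=O)/C(O)=C/C(=O)c1cn(Cc2cccc(F)c2)c2cccc(OC)c12`, gives 63200 nM;
compound 2, `COc1cccc2c1c(C(=O)/C=C(\O)C(=O)O)cn2Cc1ccc(F)c(F)c1F`, gives 22800 nM;
compound 3, `CCOC(=O)/C(O)=C/C(=O)c1cn(Cc2ccc(F)cc2F)c2cccc(OC)c12`, gives 65500 nM.

In this assay compound 3 stands at the highest of the three numbers. Compound 1 lies within the scatter of it, so no order between those two can be read, while compound 2 lies lower, beyond the scatter. Compound 2 differs from compound 3 in more than one place, however, so its value alone does not isolate any single change.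

The step to compound 4, `CCOC(=O)/C(O)=C/C(=O)c1cn(Cc2ccc(F)c(F)c2F)c2cccc(OC)c12`, is fluoro in place of hydrogen on an aromatic carbon. Going by the values given here, the only measured step that touches the same ring, a 1.0-fold higher number from compound 1 to compound 3 (0.02 log units; within the scatter), stayed within the scatter, which suggests that rearranging or adding fluoro there moves the number little. A slight downward lean is allowed since compound 2 gives 22800 nM, but its second difference clouds that reading. Compound 4 is therefore expected to give about 50000 nM, in a range from 22000 nM to 110000 nM. The expected step is a 1.3-fold lower number from compound 3 to compound 4 (0.12 log units; within the scatter), not beyond the scatter.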

Compound 4, half-maximal cytotoxic concentration: 42700 nM
Beside the measured number, compound 4's estimate is 1.2-fold (0.07 log units) above it; low and high end bracket the measured number.
By their numbers in this assay, from the lowest: compounds 2, 4, 1 and 3 (each within the scatter of the next, the first and the last beyond it).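

In this assay, the step to 2,3,4-trifluorobenzyl, a 1.5-fold lower number from compound 3 to compound 4 (0.19 log units; within the scatter), shows that this aromatic carbon takes fluoro without a readable shift, and the wider change of the fluorinated group, a 1.5-fold lower number from compound 1 to compound 4 (0.17 log units; within the scatter), reads the same way. Going by these compounds alone, compound 4 also gives the first single-change reading of the ethyl group on the ester oxygen, a 1.9-fold higher number from compound 2 to compound 4 (0.27 log units; within the scatter), so that change too stays inside the scatter, whereas the gap between compound 2 and compound 3 could not be tied to one change. No measured evidence accounts for these numbers.

The compounds shown leave open whether a larger group at this aromatic carbon, such as chloro or a methyl ether, would shift the number beyond the scatter in this assay. They also leave open how an amide in place of the ester would read.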